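A Sugar Added to a Macrocycle at the Limit

This account rests on a few compounds, and the source may have more. Where it says the series, first, only, none or still open, it means among the compounds named here.

Compound 1 `COc1c2cc(c(OC)c1O)Oc1ccc(cc1)[C@@H](O)C[C@@H](O)CC/C=C\2` and compound 2 `COc1c2cc(c(OC)c1O)Oc1ccc(cc1)[C@@H](O)C[C@@H](O)/C=C/C=C\2` open the series. In a functional assay on U2OS cells (Homo sapiens) for cytotoxicity, read by spectrophotometry and crystal violet staining, with a stated time of 24 h (on this read-out lower numbers stand for an effect already at smaller amounts and higher numbers for an effect only at larger amounts of compound), compound 1 reaches only the limit of the measurement, at > 150000 nM. Compound 2 likewise gives only a limit in this assay, at > 150000 nM. Compound 3 `O=C1CCc2ccc(O)c(c2)-c2cc(ccc2O)C[C@H](O)C[C@H]1O` stands at the same place: in this assay compound 3 shows only a limit, > 150000 nM, so that all three values shown sit at the limit of > 150000 nM in this assay, at which 3 of the 3 values shown sit, and no number separates them. Compound 4 `O=C1CCc2ccc(O)c(c2)-c2cc(ccc2O)C[C@H](O[C@@H]2O[C@H](CO)[C@H](O)[C@@H](O)[C@H]2O)C[C@H]1O` has not been measured; it differs from compound 3 by a group of 11 heavy atoms (6 carbon, 5 oxygen; one six-membered non-aromatic ring with 1 hetero atom) in place of a hydrogen atom, on an oxygen on a saturated carbon. With every measured value at the limit, the step of a number no higher from compound 3 to compound 4 (the limit leaves the size open) is expected to be none beyond the scatter. Compound 4 is therefore estimated at 150000 nM, within 50000 nM to 400000 nM, and most likely again reported only as a limit.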

Compound 4, half-maximal effective concentration: > 150000 nM
Compound 4: only a limit was reported (the forecaster's own chance of this, stated with the estimate: 85%); the middle value sits exactly at the limit.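

Going by these compounds alone, compound 3 and compound 4 are both reported only as limits, and no step between them can be read. The compounds shown leave open whether any of the four differs from another in this assay at all.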